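Removing the methoxy: compound 2 to compound 3

A few compounds are considered here, and "the series" means these few. Any claim that something is new, unique, unknown or untested is made for them only; others in the source may bear on it.

Measured so far:
compound 1, `N#C/C(=C\c1c(-c2ccccc2)[nH]c2ccccc12)C(=O)c1ccccc1` — "not determined" (no result reported)
compound 2, `COc1ccc(-c2[nH]c3ccccc3c2/C=C(\C#N)S(=O)(=O)c2ccccc2)cc1` — 350 nM

Within the data shown here, in a functional assay on SR cells (Homo sapiens) for inhibition, read by sulforhodamine B assay, with a stated time of 48 h (a higher number here means a weaker inhibitor of growth, a lower number a stronger inhibitor of growth), compound 2 gives 350 nM, the only number; compound 1 gives "not determined" (no result reported), no result. Compound 3, `N#C/C(=C\c1c(-c2ccccc2)[nH]c2ccccc12)S(=O)(=O)c1ccccc1`, is the next entry. It differs from compound 2 by hydrogen in place of methoxy on an aromatic carbon. Among the measured compounds shown here, no step between measured compounds exists to set a size for this change, so the expectation is a step of roughly a 1.4-fold higher number from compound 2 to compound 3 (0.15 log units; within the scatter), not clearly beyond the scatter. Compound 3 is thus estimated at 500 nM in this assay, within 150 nM to 1500 nM.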

Compound 3, concentration for 50% growth inhibition: 17300 nM
For compound 3 the middle estimate is 35-fold (1.54 log units) below the measured one; the measured number lies above the stated range.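

In this assay, hydrogen in place of methoxy on an aromatic carbon gives a 49-fold higher number from compound 2 to compound 3 (1.69 log units; beyond the scatter) and so sets the first size for a single change in this series. Growth inhibition in this pair therefore depends strongly on what stands on this carbon, para to a large group, although that reading rests on one pair alone. The data at hand offer no explanation for the size of this step.

Still open, going by these compounds, is whether the higher potency of compound 2 is specific to methoxy or also appears with ethoxy, hydroxyl, fluorine or an amine on the same carbon. Also open, on these data alone, is whether the same change keeps its size on a compound with a carbonyl in place of the sulfonyl.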